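Notes on the halogen swap from compound 3 to compound 4

The source may report more compounds than this note shows. Statements on the series, on what has been measured and on what is new or still open speak of the compounds shown alone.

Compound 3 `Cn1c(=O)[nH]c2c(cnn2-c2ccccc2Cl)c1=N` gives 7% in an assay on membranes from brain for binding affinity to adenosine receptor A1 (Rattus norvegicus), read by radioligand binding, tested at 20 uM; on this read-out lower numbers stand for less inhibition and higher numbers for more inhibition at the one concentration tested (going by the name of the read-out). Compound 2 `Cn1c(=O)[nH]c2c(cnn2-c2ccccc2F)c1=N` gives 8% and compound 1 `Cn1c(=O)[nH]c2c(cnn2-c2ccccc2[N+](=O)[O-])c1=N` gives 5%; the three numbers lie within the scatter of each other, and compound 3 sits neither at the top nor at the bottom of this narrow spread. Compound 4 `Cn1c(=O)[nH]c2c(cnn2-c2ccccc2Br)c1=N` has not been measured yet; it differs from compound 3 by bromo in place of chloro on an aromatic carbon. Among the compounds with values here, the steps that bear on this change are the exchanges already seen at the same aromatic carbon: a number 1 percentage points lower from compound 2 to compound 3 (within the scatter), and, from the nitro starting point, a number 3 percentage points higher from compound 1 to compound 2 (within the scatter) and a number 2 percentage points higher from compound 1 to compound 3 (within the scatter). None of these moved the number beyond the scatter, and one more exchange of one halogen for another at that position gives no ground to expect anything different. The expected step in this assay is therefore no change at the digits printed from compound 3 to compound 4 (within the scatter), with no direction beyond the scatter. Compound 4 is estimated at 7%, with a range from 0% to 17%.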

Compound 4, a percentage reported as inhibition, at one concentration (the size of the read-out at that concentration, not a potency): 6%
Beside the measured number, compound 4's estimate is 1 percentage points above it; measured number inside the range.
By their numbers in this assay, from the lowest: compounds 1, 4, 3 and 2 (each within the scatter of the next).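

With bromo, the set of groups on this aromatic carbon, ortho to a large group, now spans three halogens and nitro, and in this assay each new comparison stays inside the scatter: a number 1 percentage points lower from compound 3 to compound 4 (within the scatter) and a number 2 percentage points lower from compound 2 to compound 4 (within the scatter) and also a number 1 percentage points higher from compound 1 to compound 4 (within the scatter) in the comparison with nitro. Every pair among these four compounds now has a printed step within the scatter, so this read-out at its one concentration sets no order among fluoro, chloro, bromo and nitro at this place. Nothing measured here speaks to why the four groups are not told apart.

Open, as far as these compounds go, is whether an amine, a carboxylic acid or a methoxy group on this same aromatic carbon would carry the number beyond the scatter. Also open, from the compounds shown here alone, is whether any halogen elsewhere on this ring, or a longer chain in place of the methyl on the shared core, would do so.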